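The compounds below may be only part of what the source reports. "The series", "measured", "known", "first", "only" and "open" are said of these compounds alone.

Compounds measured so far:
compound 1 `COc1ccc(-c2cc(/C=C/C(=O)c3ccc(N)cc3)[nH]n2)cc1` — 65%
compound 2 `COc1cc(-c2cc(/C=C/C(=O)c3ccc(N)cc3)[nH]n2)cc(OC)c1OC` — 76%
compound 3 `COc1cc(-c2cc(/C=C/C(=O)c3ccc(Cl)c(Cl)c3)[nH]n2)cc(OC)c1OC` — 87%

In a functional assay on U-251 cells (Homo sapiens) for cytotoxicity, read by sulforhodamine B assay, with a stated time of 48 h, tested at 1 uM (a lower number here means a stronger effect, a higher number a weaker effect of the compound at the concentration tested), compound 3 gives 87%, the highest of the three numbers shown. Compound 2 gives 76%, and compound 1 gives 65%. Going by the values given here, the only step from one change alone is a number 11 percentage points higher from compound 2 to compound 3 (beyond the scatter); compound 1 and compound 2 share the same group on the carbonyl carbon and differ elsewhere.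

Compound 4 `COc1cc(-c2cc(/C=C/C(=O)c3ccc(F)c(F)c3)[nH]n2)cc(OC)c1OC` changes compound 3 in one place: 3,4-difluorophenyl in place of 3,4-dichlorophenyl on a carbonyl carbon. Among the compounds with values here, no measured pair swaps one halogenated group for another, so the one step available bears on it only loosely. A small step is therefore expected, a number 5 percentage points lower from compound 3 to compound 4 (within the scatter), not clearly beyond the scatter. Compound 4 is expected to give about 82% in this assay, within 68% to 96%.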

Compound 4, a percentage reported as activity, at one concentration (the size of the read-out at that concentration, not a potency): 87%
Compound 4: the middle estimate sits 5 percentage points below what was measured, and the stated range covers the measured number.
By their numbers in this assay, from the lowest: compound 1; then compound 2; then compounds 3 and 4 (each within the scatter of the next).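

In this assay the exchange of halogens on the phenyl at the carbonyl carbon gives no change at the digits printed from compound 3 to compound 4 (within the scatter) and so 3,4-dichlorophenyl and 3,4-difluorophenyl read alike at this position. The exchange of 4-aminophenyl for 3,4-difluorophenyl gives a number 11 percentage points higher from compound 2 to compound 4 (beyond the scatter) and matches a number 11 percentage points higher from compound 2 to compound 3 (beyond the scatter) in direction and printed size, so that step is not tied to chlorine. Nothing available explains this match. Open, from the compounds shown here alone, is whether the shift follows the halogens or the absence of the amine, and whether an unsubstituted phenyl or 4-hydroxyphenyl would read with the dihalophenyl pair or with 4-aminophenyl.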